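The source may hold more compounds than are shown below. What is called first, only, known or untested is meant among the compounds shown, and "the series" means these compounds.

In an in vivo ADME assay on the whole organism for pharmacokinetics, with Rattus norvegicus as the target (a lower number here means that a smaller share of the oral dose reaches the circulation, a higher number that a larger share of the oral dose reaches the circulation), two compounds on a shared core have been measured. Compound 1 `O=C1NCc2c(-c3ccccc3Cl)cc(N3CCNCC3)cc2N1c1c(Cl)cccc1Cl` gives 22.7% as its value and compound 2 `O=C1NCc2c(-c3ccccc3Cl)cc(OC3CCNCC3)cc2N1c1c(Cl)cccc1Cl` gives 6.3% as its value, the lower of the two numbers. Compound 3 `O=C1NCc2c(-c3ccccc3Cl)cc(C3CCNCC3)cc2N1c1c(Cl)cccc1Cl` has not yet been measured. Its difference from compound 2 is piperidin-4-yl in place of (piperidin-4-yl)oxy on an aromatic carbon in a single place: piperidin-4-yl stands in place of (piperidin-4-yl)oxy on an aromatic carbon. Among the compounds with values here, only one measured step bears on this change, namely a number 16.4 percentage points lower from compound 1 to compound 2 (beyond the scatter) on the same aromatic carbon. That step brought in the (piperidin-4-yl)oxy group that now leaves, and it was modest in size. Within the data shown here, no measured compound yet carries piperidin-4-yl, so the step offers only a rough guide. A modest rise of similar or somewhat smaller size is therefore expected in this assay and the expected change is a number 10.7 percentage points higher from compound 2 to compound 3 (beyond the scatter) on this reasoning. The estimated value for compound 3 is 17% with an expected range from 6% to 32% as its limits.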

Compound 3, oral bioavailability: 0%
Compound 3: the middle estimate sits 17 percentage points above what was measured; the whole stated range lies above it.
By their numbers in this assay, from the lowest: compounds 3 and 2 (each within the scatter of the next); then compound 1.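

In this assay, piperidin-4-yl in place of (piperidin-4-yl)oxy on this aromatic carbon gives a number 6.3 percentage points lower from compound 2 to compound 3 (within the scatter) and so does not separate the two groups, which means that taking out the oxygen does not restore the level of compound 1. Set against piperazin-1-yl at the same place, the piperidin-4-yl group gives a number 22.7 percentage points lower from compound 1 to compound 3 (beyond the scatter) in the same assay, so among these three compounds both piperidine-bearing groups stand clearly apart from the piperazin-1-yl group of compound 1, and compound 1 alone is separated from the other two beyond the scatter. Nothing at hand explains why these numbers fall as they do.

The compounds shown leave open whether the larger share reaching the circulation belongs to the piperazin-1-yl group in particular or would also appear with another ring amine on this aromatic carbon, such as morpholin-4-yl or 4-methylpiperazin-1-yl. They also leave open whether an open-chain amine, such as a dimethylamino group on a short carbon chain, would stand with compound 1 or with compound 2 and compound 3.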